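The source may report more compounds than this note shows. Statements on the series, on what has been measured and on what is new or still open speak of the compounds shown alone.

Measured so far, in a functional assay on PC-3 cells (Homo sapiens) for inhibition, read by MTT assay, with a stated time of 48 h; a lower number here means a stronger inhibitor, a higher number a weaker inhibitor: compound 1 `COc1cc(N(Cc2ccc(Br)cc2)S(=O)(=O)c2ccc(C)cc2)cc(OC)c1OC` gives 4680 nM, and compound 2 `COc1cc(N(Cc2csc3ccc(Cl)cc23)S(=O)(=O)c2ccc(C)cc2)cc(OC)c1OC` gives 15300 nM.

Compound 2 has the highest number of the two, so it is the weaker inhibitor; its nearest neighbour is compound 1, and the step of a 3.3-fold higher number from compound 1 to compound 2 (0.51 log units; beyond the scatter) is beyond the scatter. Compound 3 `COc1cc(N(Cc2nc3ccccc3[nH]2)S(=O)(=O)c2ccc(C)cc2)cc(OC)c1OC` has not yet been measured. It differs from compound 2 in one place: 1H-benzimidazol-2-yl in place of 5-chloro-1-benzothiophen-3-yl on a saturated chain carbon bound to a sulfonamide nitrogen.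

Going by the values given here, the only measured step at this position, a 3.3-fold higher number from compound 1 to compound 2 (0.51 log units; beyond the scatter), shows that exchanging the group on the saturated chain carbon bound to the sulfonamide nitrogen can move the number by a modest amount. Here a fused ring group is swapped for another fused ring group, one that carries a hydrogen-bond donor and lacks the chlorine. Among the compounds with values here, no measured pair shows what such a swap does, so the direction is open; a step of about the size seen between compound 1 and compound 2 is plausible either way, and a step within the scatter is equally plausible.

The estimate for compound 3 in this assay is therefore 12000 nM, within 4000 nM to 40000 nM, which means an expected step of a 1.3-fold lower number from compound 2 to compound 3 (0.11 log units; within the scatter).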

Compound 3, half-maximal inhibitory concentration: 3340 nM
Compound 3: middle estimate off by 3.6-fold (0.56 log units), on the high side; the whole stated range lies above it.
By their numbers in this assay, from the lowest: compounds 3 and 1 (each within the scatter of the next); then compound 2.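

In this assay, exchanging one fused ring group for another on a saturated chain carbon bound to a sulfonamide nitrogen has a clear effect: 1H-benzimidazol-2-yl in place of 5-chloro-1-benzothiophen-3-yl gives a 4.6-fold lower number from compound 2 to compound 3 (0.66 log units; beyond the scatter), a shift larger than the scatter. A fused ring group at this place therefore does not by itself go with the higher number, as compound 2 and compound 3 both carry one yet differ clearly. Replacing the 4-bromophenyl group of compound 1 with 1H-benzimidazol-2-yl gives a 1.4-fold lower number from compound 1 to compound 3 (0.15 log units; within the scatter), so these two compounds cannot be told apart, even though one carries a single ring and the other a fused pair.

No measurement shown here explains why the number moves when the 5-chloro-1-benzothiophen-3-yl group is replaced. From the compounds shown here alone, that replacement removes the sulfur and chlorine and brings in two nitrogens and a hydrogen-bond donor all at once, so it remains open which of these changes matters, and also how an amine or a longer chain would behave at this place.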